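The compounds below may be only part of what the source reports. "The series", "measured", "known", "first", "only" and "open" are said of these compounds alone.

Compound 1 `Cc1cccc2c1nc(COc1ccc(Cl)cc1)n2CCCC1CCN(CCCc2ccccc2)CC1`: 57 nM
Compound 2 `CCOC(=O)CCCN1CCC(CCCn2c(COc3ccc(Cl)cc3)nc3c(C)cccc32)CC1`: 29 nM

In an assay on AV12 cells for binding affinity to Neuropeptide Y receptor type 1 (Homo sapiens) (on this read-out lower numbers stand for stronger inhibition and higher numbers for weaker inhibition), compound 2 gives 29 nM, while compound 1 gives 57 nM; the two lie within the usual scatter of each other, as a 2.0-fold lower number from compound 1 to compound 2 (0.29 log units; within the scatter) shows. Compound 3 `Cc1cccc2c1nc(COc1ccc(Cl)cc1)n2CCCC1CCN(CC(=O)O)CC1` is not yet measured. It differs from compound 2 by carboxy in place of 2-(ethoxycarbonyl)ethyl on a saturated chain carbon bound to an amine nitrogen in a ring. For the measured compounds named here, only one measured step touches this region of the molecule: the exchange of phenyl for ethoxycarbonyl three bonds out from the ring amine, which gave a 2.0-fold lower number from compound 1 to compound 2 (0.29 log units; within the scatter), so the tail attached to that amine tolerated a change of end group without a shift beyond the scatter. Going by the values given here, compound 3, however, also loses most of the chain and carries a free acid instead of an ester, and no measured pair speaks to that. A modest step toward a higher number is therefore expected, a 2.8-fold higher number from compound 2 to compound 3 (0.44 log units; beyond the scatter), and compound 3 is estimated at 80 nM, within 20 nM to 400 nM.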

Compound 3, inhibition constant: 2190 nM
Compound 3: the middle estimate sits 27-fold (1.44 log units) below what was measured; the whole stated range lies below it.
By their numbers in this assay, from the lowest: compounds 2 and 1 (each within the scatter of the next); then compound 3.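

In this assay, for the compounds shown here, the swap to carboxy gives a 76-fold higher number from compound 2 to compound 3 (1.88 log units; beyond the scatter) and, measured against the phenethyl tail, a 38-fold higher number from compound 1 to compound 3 (1.58 log units; beyond the scatter) as well, so the tail on the ring amine nitrogen is far less forgiving than the earlier compounds suggested. The step of a 2.0-fold lower number from compound 1 to compound 2 (0.29 log units; within the scatter) stayed within the scatter, but it changed only the end group of a chain of the same length, whereas compound 3 both shortens the chain and ends it in carboxy instead of an ester. Nothing measured here explains this loss.

The compounds shown leave open whether the shorter chain, the carboxy group or the two together account for the step. A carboxylic acid on the longer chain of compound 2, or an ethyl ester on the short carboxymethyl tail of compound 3, would separate these two changes.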